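Substituent changes and cytotoxicity across three measured compounds

The compounds below may be only part of what the source reports. "The series", "measured", "known", "first", "only" and "open" are said of these compounds alone.

Measured so far:
compound 1 `CCc1ccc(CN[C@@H]2C[C@H]3C[C@@H]([C@H]2C)C3(C)C)s1`: 1560 nM
compound 2 `C[C@H]1[C@H](NCc2cccs2)C[C@H]2C[C@@H]1C2(C)C`: 25000 nM
compound 3 `C[C@H]1[C@H](NCc2cc(C3CC3)cs2)C[C@H]2C[C@@H]1C2(C)C`: 25000 nM

In an ADME assay on MDCK cells (Canis lupus familiaris) for cytotoxicity, read by microscopy, with a stated time of 48 h (on this read-out lower numbers stand for higher toxicity in this test and higher numbers for lower toxicity in this test), compound 2 gives 25000 nM, level with compound 3 at the digits given; together they are the highest numbers of the three. Compound 1 sits lowest, the step being a 16-fold higher number from compound 1 to compound 2 (1.20 log units; beyond the scatter).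

Compound 4 `C[C@H]1[C@H](NCc2sccc2C2CCCC2)C[C@H]2C[C@@H]1C2(C)C` differs from compound 2 by cyclopentyl in place of hydrogen on an aromatic carbon. Among the measured compounds shown here, two steps bear on this. Adding a small carbocycle gave no change at the digits printed from compound 2 to compound 3 (within the scatter), while an open-chain group on the ring gave a 16-fold higher number from compound 1 to compound 2 (1.20 log units; beyond the scatter) in reverse. The entering group is larger than cyclopropyl, so a moderate drop in the number is expected, a 2.5-fold lower number from compound 2 to compound 4 (0.40 log units; beyond the scatter), though the cyclopropyl result argues for caution. Compound 4 is expected at 10000 nM, with a range of 3000 nM to 25000 nM.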

Compound 4, minimum cytotoxic concentration: 12500 nM
Beside the measured number, compound 4's estimate is 1.3-fold (0.10 log units) below it; the measured number falls inside the stated range.
By their numbers in this assay, from the lowest: compound 1; then compounds 4, 2 and 3 (each within the scatter of the next).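

In this assay, cyclopentyl on this aromatic carbon, two ring bonds from the ring sulfur, gives a 2.0-fold lower number from compound 2 to compound 4 (0.30 log units; within the scatter). A carbocycle of this size therefore leaves the number within the scatter of the unsubstituted compound at this position, so even this larger group does not reproduce the step seen between compound 1 and compound 2. No measured property of these compounds accounts for this result. As far as these compounds go, it remains open whether an amine or a carboxylic acid on this aromatic carbon would move the number beyond the scatter. Also open, from the compounds shown here alone, is how ethyl would behave at this position.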